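Naphthalen-1-yl amine variant of an acetylated diterpenoid lactone

This account rests on a few compounds, and the source may have more. Where it says the series, first, only, none or still open, it means among the compounds named here.

Measured in a functional assay on KB cells (Homo sapiens) for cytotoxicity, read by sulforhodamine B assay; a lower number here means a stronger inhibitor, a higher number a weaker inhibitor:
- compound 1 `C=C1[C@@H](C/C=C2/C(=O)OC[C@H]2OC(C)=O)[C@]2(C)CC[C@@H](OC(C)=O)[C@@](C)(CO[Si](C)(C)C(C)(C)C)[C@H]2C[C@@H]1O`: 9790 nM
- compound 2 `C=C1[C@@H](OC(C)=O)C[C@@H]2[C@](C)(CO[Si](C)(C)C(C)(C)C)[C@H](OC(C)=O)CC[C@@]2(C)[C@@H]1C[C@@H](Nc1ccc(OC)cc1)C1=CCOC1=O`: 5630 nM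
- compound 3 `C=C1[C@@H](OC(C)=O)C[C@@H]2[C@](C)(COC=O)[C@H](OC(C)=O)CC[C@@]2(C)[C@@H]1C[C@@H](Nc1ccc(O)cc1)C1=CCOC1=O`: 28900 nM

Compound 2 gives the lowest of the three numbers in this assay. Its nearest neighbour is compound 1, whose value lies within the scatter of that of compound 2; compound 3 stands furthest away, beyond the scatter. No pair of these compounds differs in only one place, so no single structural step can be tied to a measured change.

Compound 4 `C=C1[C@@H](OC(C)=O)C[C@@H]2[C@](C)(CO[Si](C)(C)C(C)(C)C)[C@H](OC(C)=O)CC[C@@]2(C)[C@@H]1C[C@@H](Nc1cccc2ccccc12)C1=CCOC1=O` is not yet measured. It differs from compound 2 by naphthalen-1-yl in place of 4-methoxyphenyl on an amine nitrogen. Going by the values given here, with no comparable step among the measured compounds, the direction is open; the expected step of a 1.4-fold lower number from compound 2 to compound 4 (0.15 log units; within the scatter) is estimated to stay within the usual scatter, with a slight lean toward a lower number. Compound 4 is therefore expected to give about 4000 nM in this assay, within a range of 1000 nM to 16000 nM.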

Compound 4, half-maximal inhibitory concentration: 8930 nM
Compound 4: the middle estimate sits 2.2-fold (0.35 log units) below what was measured; low and high end bracket the measured number.
By their numbers in this assay, from the lowest: compounds 2, 4 and 1 (each within the scatter of the next); then compound 3.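

Going by these compounds alone, the first step that can be read at this position is a 1.6-fold higher number from compound 2 to compound 4 (0.20 log units; within the scatter) in this assay, for naphthalen-1-yl in place of 4-methoxyphenyl on the amine nitrogen. So on this amine nitrogen, with the rest of the molecule unchanged, a group of two six-membered aromatic rings and no hydrogen-bond acceptor gives a number that cannot be told apart from that of the 4-methoxyphenyl group. Nothing in the available data accounts for this step or ties it to any property of either group.

Still open, on these data alone, is whether a plain phenyl, a pyridine ring, a benzyl group or a short alkyl chain on this nitrogen would move the number beyond the scatter. As far as these compounds go, it also remains open whether the same exchange would read alike on the core of compound 3.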